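The source may report more compounds than this note shows. Statements on the series, on what has been measured and on what is new or still open speak of the compounds shown alone.

Working notes on the benzoate ester series.

Compound 1 `CC1=CC[C@H](C(C)C)c2cc(C)c(OC(=O)c3ccccc3)cc21` carries the unsubstituted benzoate on the shared core; in a functional assay on SK-LU-1 cells (Homo sapiens) for antiproliferative activity, read by sulforhodamine B assay, with a stated time of 48 h, tested at 50 uM (on this read-out higher numbers stand for more inhibition at the one concentration tested (going by the name of the read-out) and lower numbers for less inhibition), compound 1 gives 37%. Compound 3 `Cc1cc2c(C(C)C)ccc(C)c2cc1OC(=O)c1ccc([N+](=O)[O-])cc1`, with a nitro group on the ester and a different core, gives 100% in this assay. Compound 2 `CC1=CC[C@H](C(C)C)c2cc(C)c(OC(=O)c3ccc(C(F)(F)F)cc3)cc21` carries a trifluoromethyl on the ester and stands without a number: in this assay compound 2 was reported as "not active" (no number reported), so nothing beyond that qualitative outcome can be said of its level. Compound 4 `COc1ccc(C(=O)Oc2cc3c(cc2C)[C@@H](C(C)C)CC=C3C)cc1` differs from compound 2 in one place: methoxy in place of trifluoromethyl on an aromatic carbon. Among the measured compounds shown here, no measured pair shows this step, so its size is unknown from the data. For the measured compounds named here, the only guide is that compound 1 gives 37% while compound 2 returns no number, which makes a move upward from the inactive level plausible but not assured; an outcome again within the scatter of no inhibition cannot be excluded. Compound 4 is expected in this assay to give about 30%, with a range from 0% to 65%.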

Compound 4, a percentage reported as inhibition, at one concentration (the size of the read-out at that concentration, not a potency): 18.6%
Beside the measured number, compound 4's estimate is 11.4 percentage points above it, within the range that was stated.
By their numbers in this assay, from the lowest: compound 4; then compound 1; then compound 3.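

In this assay, among the compounds shown here, this is the first measured step at this position on the shared core: a number 18.4 percentage points lower from compound 1 to compound 4 (beyond the scatter). Methoxy in place of hydrogen on an aromatic carbon, para to a large group, therefore lowers inhibition here rather than raising it. The step between compound 2 and compound 4 cannot be read, since compound 2 has only the qualitative outcome "not active", and no evidence at hand bears on the origin of the methoxy result.

For the compounds shown here, whether the trend holds for other groups remains open, since methoxy is the only substituent with a number on the shared core. How a nitro group, an amine or a carboxylic acid at this position on that core would read in this assay also stays unresolved, and compound 3 cannot answer this, as its core differs too.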